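The compounds below may be only part of what the source reports. "The series", "measured", "known", "first", "only" and "open" are said of these compounds alone.

Compound 1 `CNc1ncnc2c1c(-c1ccoc1)cn2[C@@H]1O[C@H](CO)[C@@H](O)[C@H]1O`: 96300 nM.
Compound 2 `O=c1[nH]cnc2c1c(-c1ccccc1)cn2[C@@H]1O[C@H](CO)[C@@H](O)[C@H]1O`: > 100000 nM, which is a limit and not a number.

Both compounds were tested in an ADME assay on BJ cells (Homo sapiens), read by MTT assay, with a stated time of 72 h; on this read-out lower numbers stand for stronger inhibition and higher numbers for weaker inhibition. Compound 2 yields no exact value, and stands at the limit of > 100000 nM in this assay, at which 1 of the 2 values shown sits. Compound 3 `O=c1[nH]cnc2c1c(-c1cc3ccccc3o1)cn2[C@@H]1O[C@H](CO)[C@@H](O)[C@H]1O` keeps the core of compound 2 and differs in one group, with 1-benzofuran-2-yl in place of phenyl on an aromatic carbon.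

Among the measured compounds shown here, no measured pair of compounds shows the effect of a change like this one. Compound 1 gives 96300 nM, so neither measured compound shows strong inhibition in this assay. On that basis, only a modest move towards stronger inhibition is expected, and possibly none beyond the scatter. The estimated change is an at least 1.4-fold lower number from compound 2 to compound 3 (0.15 log units; that floor lies within the scatter). For compound 3 the estimated value is 70000 nM, with an expected range of 20000 nM to 100000 nM.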

Compound 3, half-maximal inhibitory concentration: 62700 nM
The estimate for compound 3 lay 1.1-fold (0.05 log units) above the measured number; measured number inside the range.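

Among the compounds shown here, for this aromatic carbon, this assay now gives a first step of an at least 1.5-fold lower number from compound 2 to compound 3 (0.20 log units; that floor lies within the scatter) for the change from phenyl to 1-benzofuran-2-yl. Compound 3 gives 62700 nM as an exact number, so with 1-benzofuran-2-yl in this place the shared core can be put on the scale, which the phenyl group on the same core did not allow. The step is only a floor because compound 2 has a limit and not a number: the limit of > 100000 nM in this assay, at which 1 of the 3 values shown sits.

As far as these compounds go, whether the true step goes beyond the usual scatter stays open. Also open, from the compounds shown here alone, is how this position responds to a different kind of group, such as an amine or a carboxylic acid in place of 1-benzofuran-2-yl, and whether the same swap would act alike on the core of compound 1.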